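The source may report more compounds than this note shows. Statements on the series, on what has been measured and on what is new or still open speak of the compounds shown alone.

The account follows the step from compound 3 to compound 4 in an in vitro functional assay on HEK285-7 cells for antagonist activity at prostaglandin D2 receptor 2 (Homo sapiens), read by BRET and beta-arrestin recruitment; a higher number here means a larger maximal response, a lower number a smaller maximal response. Compound 1 `O=C(O)Cc1sc(C(c2ccccc2)c2ccccc2)nc1-c1ccc(F)cc1` gives 80% in this assay. Compound 2 `O=C(O)Cc1sc(C(c2ccccc2)c2ccc(Cl)cc2)nc1-c1ccc(F)cc1`, with chloro in place of hydrogen on an aromatic carbon, gives 80%, and the step shows no change at the digits printed from compound 1 to compound 2 (within the scatter). Compound 3 `O=C(O)Cc1sc(C(c2ccccc2)c2ccc(O)cc2)nc1-c1ccc(F)cc1`, with hydroxy in place of hydrogen on an aromatic carbon, gives 80%, so that no change at the digits printed from compound 1 to compound 3 (within the scatter) and no change at the digits printed from compound 2 to compound 3 (within the scatter). Compound 3 thus stands level with compounds 1 and 2 at the digits shown, nearest to compound 1 and furthest from compound 2, with neither gap beyond the scatter.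

Compound 4 `O=C(O)Cc1sc(C(c2ccccc2)c2ccc(F)c(F)c2)nc1-c1ccc(F)cc1` has not yet been measured. It differs from compound 3 in one place: 3,4-difluorophenyl in place of 4-hydroxyphenyl on a saturated chain carbon bound to two aromatic carbons. For the measured compounds named here, the three measured steps each alter a substituent on an aromatic carbon, and none of them moved the maximal response beyond the scatter, which is the only evidence that bears on the present exchange. On that basis the step from compound 3 to compound 4 is expected to be no change at the digits printed from compound 3 to compound 4 (within the scatter), with no change beyond the scatter in either direction. Compound 4 is therefore estimated to give 80% in this assay, within a range from 65% to 95%.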

Compound 4, largest response reached (reported as efficacy), in percent of the reference or control that the assay uses: 80%
Estimate against measurement, compound 4: no gap at the digits printed; measured number inside the range.
By their numbers in this assay, from the lowest: compounds 1, 2, 3 and 4 (each within the scatter of the next).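

In this assay, replacing the whole aryl group on a saturated chain carbon bound to two aromatic carbons gives no change at the digits printed from compound 3 to compound 4 (within the scatter), and the same reading holds for the exchange of 4-chlorophenyl, with no change at the digits printed from compound 2 to compound 4 (within the scatter), and of phenyl, with no change at the digits printed from compound 1 to compound 4 (within the scatter). Where the earlier compounds differed by a single substituent on this aryl group, 3,4-difluorophenyl brings two fluorine atoms and, against 4-hydroxyphenyl, has neither the hydrogen-bond donor nor the hydrogen-bond acceptor, and the maximal response stays level across all of these exchanges. Nothing given here accounts for why the response stays level across these groups.

From the compounds shown here alone, every group compared at this position contains a six-membered aromatic ring of carbon only, so it remains open whether an amine, a carboxylic acid or a longer chain there would leave the maximal response level as well. The rest of the core of compound 1 is the same in all four compounds, which leaves open what an exchange of the acetic acid chain or the 4-fluorophenyl group would do.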